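The source may report more compounds than this note shows. Statements on the series, on what has been measured and on what is new or still open speak of the compounds shown alone.

Working notes on the series. All three measured compounds share one core and differ only at the saturated chain carbon bound to a double-bonded chain carbon. Compound 1 `CCC/C(=C(/c1ccc(/C=C/C(=O)O)cc1)c1ccc2[nH]ncc2c1)c1ccccc1` gives 11 nM in a functional assay on MCF7 cells (Homo sapiens) for cytotoxicity, read by CellTiter-Glo, with a stated time of 5 days; a lower number here means a stronger inhibitor, a higher number a weaker inhibitor. Compound 2 `CCCC/C(=C(/c1ccc(/C=C/C(=O)O)cc1)c1ccc2[nH]ncc2c1)c1ccccc1` gives 10 nM in this assay, and the step of a 1.1-fold lower number from compound 1 to compound 2 (0.04 log units; within the scatter) lies within the scatter. Compound 3 `COC/C(=C(/c1ccc(/C=C/C(=O)O)cc1)c1ccc2[nH]ncc2c1)c1ccccc1` gives 88 nM in this assay, the highest of the three numbers; the steps of an 8.0-fold higher number from compound 1 to compound 3 (0.90 log units; beyond the scatter) and an 8.8-fold higher number from compound 2 to compound 3 (0.94 log units; beyond the scatter) are both beyond the scatter and both modest.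

Compound 4 `O=C(O)/C=C/c1ccc(/C(=C(/CCF)c2ccccc2)c2ccc3[nH]ncc3c2)cc1` is not yet measured. The change from compound 3 is fluoromethyl in place of methoxy on a saturated chain carbon bound to a double-bonded chain carbon. Within the data shown here, the steps that bear on it are the two into compound 3, where an alkyl at the same place was exchanged for methoxy and the number rose by a modest amount each time. Fluoromethyl is not one of those alkyls, and no measured step maps methoxy to fluoromethyl directly, so the size of the return is uncertain. A lower number is therefore expected in this assay for compound 4, though not necessarily a full return to the numbers of compounds 1 and 2. The expected step is a 3.5-fold lower number from compound 3 to compound 4 (0.55 log units; beyond the scatter). Compound 4 is estimated to give about 25 nM, with a range from 10 nM to 70 nM.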

Compound 4, half-maximal inhibitory concentration: 2.1 nM
For compound 4 the middle estimate is 12-fold (1.08 log units) above the measured one; measured number outside the range, below it.
By their numbers in this assay, from the lowest: compound 4; then compounds 2 and 1 (each within the scatter of the next); then compound 3.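

In this assay the exchange of methoxy for fluoromethyl on a saturated chain carbon bound to a double-bonded chain carbon gives a 42-fold lower number from compound 3 to compound 4 (1.62 log units; beyond the scatter), a large step that goes well past a simple return to the alkyl compounds. The same comparison against those alkyl compounds gives a 4.8-fold lower number from compound 2 to compound 4 (0.68 log units; beyond the scatter) and a 5.2-fold lower number from compound 1 to compound 4 (0.72 log units; beyond the scatter), both modest and beyond the scatter, so this position separates 2-fluoroethyl from the plain alkyl chains, whereas lengthening the alkyl chain between compound 1 and compound 2 changed nothing beyond the scatter. No measured property is available here that bears on these differences.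

The compounds shown leave open whether a 2-chloroethyl or a 2,2-difluoroethyl chain at the same place would keep the low number of compound 4 or lose it. A 3-fluoropropyl chain would show whether the place of the fluorine along the chain matters as much as its presence, and a 2-hydroxyethyl chain would show how far the result is tied to fluorine at all.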